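This account rests on a few compounds, and the source may have more. Where it says the series, first, only, none or still open, it means among the compounds named here.

In a functional assay on A-375 cells (Homo sapiens) for inhibition, read by CCK-8 assay, with a stated time of 72 h, tested at 8 uM (on this read-out lower numbers stand for less inhibition of growth and higher numbers for more inhibition of growth at the one concentration tested), compound 1 (`Cc1cc(C)cc(SCc2ccc(/C=C/C(=O)Nc3ccccc3N)cc2)c1`) stands at 2.49% and compound 2 (`CCc1ccc(SCc2ccc(/C=C/C(=O)Nc3ccccc3N)cc2)cc1`) at 58.4% while compound 3 (`Cc1ccc(SCc2ccc(C(=O)Nc3ccccc3N)cc2)cc1`) gives 67% on the same read-out. Compound 2 thus sits level with compound 3 within the scatter and far above compound 1. The change under review leads to compound 4 (`Nc1ccccc1NC(=O)/C=C/c1ccc(CSCCc2ccccc2)cc1`), with phenethyl in place of 4-ethylphenyl on a sulfur. Going by the values given here, only one measured step bears on this, also a swap of the group on that sulfur (a number 55.9 percentage points higher from compound 1 to compound 2 (beyond the scatter)), and it is large and beyond the scatter. Among the compounds with values here, it shows that the read-out can respond strongly to a change at this place, but no measured compound carries phenethyl, so the data do not fix a direction. A fall is judged the more likely outcome, with compound 2 at 58.4% already among the highest numbers seen. The estimated step (a number 16.4 percentage points lower from compound 2 to compound 4 (beyond the scatter)) is expected to be moderate and downward, with a wide margin. For compound 4 the expected value is 42% with 12% to 68% as the estimated range.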

Compound 4, percent growth inhibition at one concentration: 37.4%
The estimate for compound 4 lay 4.6 percentage points above the measured number; the range from low to high includes it.
By their numbers in this assay, from the lowest: compound 1; then compound 4; then compounds 2 and 3 (each within the scatter of the next).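

Phenethyl in place of 4-ethylphenyl on the sulfur gives a number 21 percentage points lower from compound 2 to compound 4 (beyond the scatter) in this assay, so the read-out separates two groups made of the same atoms, joined differently. Phenethyl in place of 3,5-dimethylphenyl gives a number 34.9 percentage points higher from compound 1 to compound 4 (beyond the scatter), which places the phenethyl group clear of both compound 1 and compound 2 rather than at either end of the range seen for this position. Nothing measured here accounts for either step.

A benzyl group or a longer chain such as phenylpropyl on the sulfur, or an amine or a carboxylic acid on the phenethyl ring, would show whether this middle level depends on chain length or on the ring substituent. From the compounds shown here alone, whether phenethyl gives a similar result on the core of compound 3 also stays open.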